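Adding a Methyl to the Propyl Chain of Compound 3

A few compounds are considered here, and "the series" means these few. Any claim that something is new, unique, unknown or untested is made for them only; others in the source may bear on it.

In a functional assay on HBL-100 cells (Homo sapiens) for antiproliferative activity, read by sulforhodamine B assay, with a stated time of 48 h (a higher number here means a weaker inhibitor of growth, a lower number a stronger inhibitor of growth), compound 3 (`CCCC(C#CC(=O)OC)O/C=C/C(=O)OC`) gives 270 nM. This lies within the scatter of both compound 1 (`CCCCC(C#CC(=O)OC)O/C=C/C(=O)OC`), at 250 nM, and compound 2 (`COC(=O)C#CC(O/C=C/C(=O)OC)C(C)c1ccccc1`), at 490 nM. Compound 4 (`CCC(C)C(C#CC(=O)OC)O/C=C/C(=O)OC`) has methyl in place of hydrogen on a saturated chain carbon bound to two saturated chain carbons, which turns propyl to sec-butyl: methyl in place of hydrogen on a saturated chain carbon bound to two saturated chain carbons. For the measured compounds named here, the only measured step on this chain, a 1.1-fold higher number from compound 1 to compound 3 (0.03 log units; within the scatter), stays within the scatter, so no step beyond the scatter is expected in this assay. The expected step is a 1.2-fold higher number from compound 3 to compound 4 (0.07 log units; within the scatter). Compound 4 is estimated at 320 nM, with an expected range from 150 nM to 650 nM.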

Compound 4, concentration for 50% growth inhibition: 340 nM
For compound 4 the middle estimate is 1.1-fold (0.03 log units) below the measured one, within the range that was stated.
By their numbers in this assay, from the lowest: compounds 1, 3, 4 and 2 (each within the scatter of the next).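

In this assay, methyl in place of hydrogen on a saturated chain carbon bound to two saturated chain carbons gives a 1.3-fold higher number from compound 3 to compound 4 (0.10 log units; within the scatter) and so leaves sec-butyl within the scatter of propyl. Sec-butyl in place of butyl gives a 1.4-fold higher number from compound 1 to compound 4 (0.13 log units; within the scatter) and ethyl in place of phenyl gives a 1.4-fold lower number from compound 2 to compound 4 (0.16 log units; within the scatter), so none of the chains shown here steps beyond the scatter. No measurement is available that explains why these groups read alike. The compounds shown leave open whether an amine, a carboxylic acid or a chain longer than butyl at this position would step beyond the scatter.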